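The compounds below may be only part of what the source reports. "The series", "measured", "known", "first", "only" and "open" are said of these compounds alone.

In an ADME assay (liver) for metabolic stability, with Liver microsome (Rattus norvegicus) as the target, using microsomes and NADPH, with a stated time of 30 min, tested at 1 uM (on this read-out lower numbers stand for slow clearance and higher numbers for fast clearance), compound 1 `Nc1ccc(S(=O)(=O)N2CCN(c3ncc(C(O)(C(F)(F)F)C(F)(F)F)cc3C3CC3)CC2)cn1` gives 27 mL.min-1.g-1, compound 2 `CCn1cc(-c2cc(C(O)(C(F)(F)F)C(F)(F)F)cnc2N2CCN(S(=O)(=O)c3ccc(N)nc3)CC2)cn1` gives 194 mL.min-1.g-1 and compound 3 `Nc1ccc(S(=O)(=O)N2CCN(c3ncc(C(O)(C(F)(F)F)C(F)(F)F)cc3-c3ccc4sccc4c3)CC2)cn1` gives 487 mL.min-1.g-1, the highest of the three. Compound 4 `Nc1ccc(S(=O)(=O)N2CCN(c3ncc(C(O)(C(F)(F)F)C(F)(F)F)cc3-c3ccc4scnc4c3)CC2)cn1` has 1,3-benzothiazol-5-yl in place of the 1-benzothiophen-5-yl of compound 3 (1,3-benzothiazol-5-yl in place of 1-benzothiophen-5-yl on an aromatic carbon). For the measured compounds named here, no measured step makes this exact swap, but two involve the same aromatic carbon: the large 18-fold higher number from compound 1 to compound 3 (1.26 log units; beyond the scatter) and the modest 2.5-fold higher number from compound 2 to compound 3 (0.40 log units; beyond the scatter). The second is the closer guide, since the group it replaces also contains nitrogen, and it points to a lower number for a nitrogen-bearing group. A modest fall is therefore expected, a 2.1-fold lower number from compound 3 to compound 4 (0.33 log units; beyond the scatter). Compound 4 is estimated at 230 mL.min-1.g-1, with an expected range from 100 mL.min-1.g-1 to 480 mL.min-1.g-1.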

Compound 4, intrinsic clearance in microsomes: 147 mL.min-1.g-1
Estimate against measurement, compound 4: 1.6-fold (0.19 log units) above, within the range that was stated.
By their numbers in this assay, from the lowest: compound 1; then compounds 4 and 2 (each within the scatter of the next); then compound 3.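

In this assay the 1,3-benzothiazol-5-yl group, with one nitrogen where 1-benzothiophen-5-yl has a carbon, gives a 3.3-fold lower number from compound 3 to compound 4 (0.52 log units; beyond the scatter) and so shows that a single atom within a group of equal size can shift clearance at this position. The same group gives a 1.3-fold lower number from compound 2 to compound 4 (0.12 log units; within the scatter) and so does not separate from 1-ethyl-1H-pyrazol-4-yl. Cyclopropyl remains lowest, with a 5.4-fold higher number from compound 1 to compound 4 (0.74 log units; beyond the scatter) even after this change.

Where a plain phenyl ring or a pyridinyl ring would fall at this carbon stays open. Nothing given here explains these shifts.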